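The source may report more compounds than this note shows. Statements on the series, on what has been measured and on what is new or still open speak of the compounds shown alone.

Three measured compounds share one core. Compound 1 `COc1cc(OC)cc(C(=O)Nc2ccc(Nc3nc(C)cc(N(C)C)n3)cc2)c1` is the largest of them, with an amide-linked part; in an ADME assay on Vero cells (Chlorocebus sabaeus) for cytotoxicity (on this read-out higher numbers stand for an effect only at larger amounts of compound and lower numbers for an effect already at smaller amounts), compound 1 gives 6310 nM. Compound 2 `COc1ccc(Nc2nc(C)cc(N(C)C)n2)cc1` lacks that part. For compound 2 this assay reports only a limit of the measurement, > 50100 nM, and not a number. Compound 3 `COc1cccc(Nc2nc(C)cc(N(C)C)n2)c1` contains the same atoms as compound 2 in a different arrangement. For compound 3 this assay again reports only a limit, > 50100 nM, so its true value is not known. Compound 3 thus stands at the limit of > 50100 nM in this assay, at which 2 of the 3 values shown sit, together with compound 2, while compound 1 alone gives a number.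

Compound 4 `COc1cc(Nc2nc(C)cc(N(C)C)n2)ccc1F` differs from compound 3 in one point: fluoro in place of hydrogen on an aromatic carbon. Among the measured compounds shown here, no measured pair shows this change, so the expected step of a number no higher from compound 3 to compound 4 (the limit leaves the size open) is none beyond the usual scatter. Compound 4 is therefore expected to give about 50100 nM, between 20000 nM and 120000 nM, most likely again as a limit only.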

Compound 4, half-maximal effective concentration: 31600 nM
For compound 4 the middle estimate is 1.6-fold (0.20 log units) above the measured one; measured number inside the range.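

In this assay compound 4 gives an actual number, 31600 nM, the only one among the compounds shown without the amide-linked part. Fluoro in place of hydrogen on this aromatic carbon, ortho to a methoxy group and para to a large group, gives an at least 1.5-fold lower number from compound 3 to compound 4 (0.20 log units; that floor lies within the scatter), so no real change can be claimed for this swap. The step stays a floor because compound 3 has only a limit and not a number: the limit of > 50100 nM in this assay, at which 2 of the 4 values shown sit.

As far as these compounds go, whether a chlorine atom, a methyl group or an amine on this same carbon would give a number like that of compound 4 remains open. The compounds shown also leave open whether fluoro would give a similar result on a ring without the methoxy group.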